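A few compounds are considered here, and "the series" means these few. Any claim that something is new, unique, unknown or untested is made for them only; others in the source may bear on it.

The measured compounds in a functional assay on HCT-116 cells (Homo sapiens) for inhibition, read by sulforhodamine B assay, with a stated time of 72 h; a higher number here means a weaker inhibitor, a lower number a stronger inhibitor:
- compound 1 `O=C(/C=C/c1cn(-c2ccccc2)nc1-c1ccsc1)c1ccccc1` gives 5100 nM
- compound 2 `O=C(/C=C/c1cn(-c2ccccc2)nc1-c1cccnc1)c1cc[nH]c1` gives 7400 nM
- compound 3 `O=C(/C=C/c1cn(-c2ccccc2)nc1-c1cccnc1)c1c[nH]c2ccccc12` gives 6400 nM

Compound 3 stands second highest of the three numbers in this assay; compound 2 lies nearest, and compound 1 furthest, and both gaps are within the scatter, so the three compounds cannot be told apart on these numbers.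

Compound 4 `O=C(/C=C/c1cn(-c2ccccc2)nc1-c1cccnc1)c1ccccc1` has not yet been measured. It differs from compound 3 in one place: phenyl in place of 1H-indol-3-yl on a carbonyl carbon. For the measured compounds named here, the only measured step at this same place is a 1.2-fold lower number from compound 2 to compound 3 (0.06 log units; within the scatter), which swaps one nitrogen-bearing ring system for another without moving the number beyond the scatter. Going by the values given here, no measured pair exchanges an indolyl for a phenyl on the carbonyl carbon, so the step to compound 4 is only loosely anchored. Compound 1, which also carries a phenyl on the carbonyl carbon, gives 5100 nM, close to the other two values. The expected step of a 1.2-fold lower number from compound 3 to compound 4 (0.07 log units; within the scatter) is therefore none beyond the scatter, and compound 4 is estimated at 5500 nM, within 2500 nM to 12000 nM.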

Compound 4, half-maximal inhibitory concentration: 2000 nM
Compound 4: the middle estimate sits 2.8-fold (0.44 log units) above what was measured; measured number below the stated range.
By their numbers in this assay, from the lowest: compound 4; then compounds 1, 3 and 2 (each within the scatter of the next).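

With this assay as the read-out, the group on the carbonyl carbon now matters: phenyl gives a 3.2-fold lower number from compound 3 to compound 4 (0.51 log units; beyond the scatter) when it replaces 1H-indol-3-yl and a 3.7-fold lower number from compound 2 to compound 4 (0.57 log units; beyond the scatter) when it replaces 1H-pyrrol-3-yl, although the two nitrogen-bearing groups stay within the scatter of each other. For the compounds shown here, with phenyl held on the carbonyl carbon, the group on the aromatic carbon also proves able to shift the number, since pyridin-3-yl in place of thiophen-3-yl gives a 2.6-fold lower number from compound 1 to compound 4 (0.41 log units; beyond the scatter) in the one pair that tests it. Nothing measured here accounts for the size of these steps.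

Going by these compounds, whether a phenyl carrying a methoxy group or a fluorine on the carbonyl carbon would shift the number further remains open. So does whether the pyridin-3-yl step holds with 1H-indol-3-yl or 1H-pyrrol-3-yl on the carbonyl carbon.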